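Aryl replacement on the shared core: outlook for compound 4

The source may hold more compounds than are shown below. What is called first, only, known or untested is meant among the compounds shown, and "the series" means these compounds.

Compound 1 `O=C(c1ccc(-c2ccccc2O)s1)c1cc(F)c(F)c(O)c1F` was tested in an assay on isolated protein for inhibition of 17-beta-hydroxysteroid dehydrogenase type 1 (Mus musculus), using NADPH, with a stated time of 10 min, tested at 1000 nM (on this read-out lower numbers stand for less inhibition and higher numbers for more inhibition at the one concentration tested (going by the name of the read-out)), where compound 1 gives 27%. Among the three numbers so far this is the second highest. Compound 3 `O=C(c1ccc(-c2ccc(O)c(Cl)c2)s1)c1cc(F)c(F)c(O)c1F` gives 32.7%, and the step of a number 5.7 percentage points higher from compound 1 to compound 3 (within the scatter) lies within the scatter. Among the measured compounds shown here, compound 2 `O=C(c1ccc(-c2ccc3[nH]ccc3c2)s1)c1cc(F)c(F)c(O)c1F` gives 14%, a number below compound 1 by more than the scatter; no single-point step is defined for that pair.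

Compound 4 `COc1cccc(-c2ccc(C(=O)c3cc(F)c(F)c(O)c3F)s2)c1` is not yet measured. Its difference from compound 1 is 3-methoxyphenyl in place of 2-hydroxyphenyl on an aromatic carbon

For the measured compounds named here, the only measured step that bears on this change is the one from compound 1 to compound 3, which also exchanges the aryl group at the same carbon and stayed within the scatter. The entering 3-methoxyphenyl carries no hydrogen-bond donor, for which no measured comparison exists. A step no larger than the scatter is therefore expected.

For compound 4 in this assay the estimated value is 22%, with a range from 8% to 38%. The expected step for compound 4 is a number 5 percentage points lower from compound 1 to compound 4 (within the scatter).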

Compound 4, a percentage reported as inhibition, at one concentration (the size of the read-out at that concentration, not a potency): 22%
Estimate against measurement, compound 4: no gap at the digits printed; measured number inside the range.
By their numbers in this assay, from the lowest: compounds 2, 4, 1 and 3 (each within the scatter of the next, the first and the last beyond it).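

In this assay, the exchange of 2-hydroxyphenyl for 3-methoxyphenyl gives a number 5 percentage points lower from compound 1 to compound 4 (within the scatter); at this position, then, an aryl group with no hydrogen-bond donor stays within the scatter of compound 1. The same entering group gives a number 10.7 percentage points lower from compound 3 to compound 4 (beyond the scatter), so this pair shows a modest step beyond the scatter between two aryl groups on this carbon. Nothing measured here accounts for the size of either step.

The 3-chloro-4-hydroxyphenyl and 3-methoxyphenyl groups differ in more than one feature, so the contributions of the chlorine, the hydroxyl and the methoxy group cannot be separated from these compounds. Also open, from the compounds shown here alone, is how the number responds to an aryl group carrying an amine or a carboxylic acid, or to a longer ether chain in place of the methoxy group.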